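The source may hold more compounds than are shown below. What is called first, only, known or untested is meant among the compounds shown, and "the series" means these compounds.

Measured in a functional assay on HCT-15 cells (Homo sapiens) for inhibition; on this read-out higher numbers stand for weaker inhibition and lower numbers for stronger inhibition:
compound 1 `Oc1cccc(-c2cc(-c3ccccc3F)cc(-c3ccccc3O)n2)c1`: 8470 nM
compound 2 `Oc1cccc(-c2cc(-c3cccc(F)c3)cc(-c3ccccc3O)n2)c1`: > 50000 nM (a limit of this assay)
compound 3 `Oc1cccc(-c2cc(-c3ccc(F)cc3)cc(-c3ccccc3O)n2)c1`: > 50000 nM (a limit of this assay)

Within the data shown here, compound 1 holds the only value in this assay that is a number. The entry for compound 2 is a limit of this assay, not a number. The entry for compound 3 is likewise a limit.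

The unmeasured compound 4 `Oc1ccc(-c2cc(-c3ccccc3F)cc(-c3cccc(O)c3)n2)cc1` differs from compound 1 in one place: 4-hydroxyphenyl in place of 2-hydroxyphenyl on an aromatic carbon. The measured steps all concern the fluorine instead: an at least 5.9-fold higher number from compound 1 to compound 2 (0.77 log units; beyond the scatter) and an at least 5.9-fold higher number from compound 1 to compound 3 (0.77 log units; beyond the scatter) move it away from the 2-position, and a step that the two limits leave unreadable from compound 2 to compound 3 cannot be read because both ends are limits. None of them touches the hydroxyphenyl group, so none bears directly on the change to compound 4; they only show that in this series a shift of a substituent around its ring has so far cost potency.

Among the measured compounds shown here, with that as the sole guide, compound 4 is expected to come out weaker than compound 1, as a step of a 3.0-fold higher number from compound 1 to compound 4 (0.47 log units; beyond the scatter). The estimate for compound 4 is 25000 nM, between 6000 nM and 50000 nM. A limit rather than a number is a real possibility, given (the limit of > 50000 nM in this assay, at which 2 of the 3 values shown sit).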

Compound 4, half-maximal inhibitory concentration: 5630 nM
Compound 4: middle estimate off by 4.4-fold (0.65 log units), on the high side, outside the stated range (below it).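

In this assay, the position next to the ring nitrogen accepts 4-hydroxyphenyl in place of 2-hydroxyphenyl with a 1.5-fold lower number from compound 1 to compound 4 (0.18 log units; within the scatter), so the two compounds cannot be told apart on this read-out and the hydroxyl shift on this ring carries no measurable cost. Moving a substituent around its ring is therefore not penalised throughout the series, since the fluorine changes on the other ring remain the only single-place changes with a step beyond the scatter, at an at least 5.9-fold higher number from compound 1 to compound 2 (0.77 log units; beyond the scatter) and an at least 5.9-fold higher number from compound 1 to compound 3 (0.77 log units; beyond the scatter), while the hydroxyl change stays within it. The step between compound 2 and compound 3 still cannot be read, and both entries remain limits of the assay rather than numbers: the limit of > 50000 nM in this assay, at which 2 of the 4 values shown sit.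

As far as these compounds go, what an aminophenyl, a methoxyphenyl, a carboxyphenyl or a plain phenyl group would give at this position stays open, so the need for a hydroxyl on this ring remains untested. Also open, from the compounds shown here alone, is whether 4-hydroxyphenyl keeps its place when the 2-fluorophenyl group is exchanged for 3-fluorophenyl or 4-fluorophenyl.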